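Working notes before compound 3 is measured

A few compounds are considered here, and "the series" means these few. Any claim that something is new, unique, unknown or untested is made for them only; others in the source may bear on it.

Compound 1 `CCNC(=O)Nc1ccc(/C=C/c2cc(C)cc(C)c2)cc1` and compound 2 `O=C1NCCN1c1ccc(/C=C/c2cccc(Cl)c2)cc1` share one core and have both been run in a functional assay on MCF7 cells (Homo sapiens) for inhibition, read by sulforhodamine B assay, with a stated time of 48 h; on this read-out lower numbers stand for stronger inhibition and higher numbers for weaker inhibition. In this assay compound 1 gives 20000 nM and compound 2 gives 20000 nM; the two values are level at the digits shown, within the scatter, so neither can be ranked above the other on these numbers. Within the data shown here, no step between measured compounds that differ in one place is available here.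

Compound 3 `Cc1cc(C)cc(/C=C/c2ccc(N3CCNC3=O)cc2)c1` is the compound to be measured next. Against compound 1 the change is 2-oxoimidazolidin-1-yl in place of (ethylcarbamoyl)amino on an aromatic carbon, placed on an aromatic carbon of a six-membered aromatic ring of carbon only, para to a large group. Among the measured compounds shown here, the entering group is the one compound 2 already carries, and compound 2 sits at the same level as compound 1 because compound 2 gives 20000 nM with that group, so no shift outside the scatter is expected. The expected step is no change at the digits printed from compound 1 to compound 3 (within the scatter), none beyond the scatter. Compound 3 is estimated at 20000 nM, within a range from 10000 nM to 40000 nM.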

Compound 3, half-maximal inhibitory concentration: 16000 nM
For compound 3 the middle estimate is 1.3-fold (0.10 log units) above the measured one, within the range that was stated.
By their numbers in this assay, from the lowest: compounds 3, 1 and 2 (each within the scatter of the next).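

In this assay, 2-oxoimidazolidin-1-yl in place of (ethylcarbamoyl)amino, on the aromatic carbon para to a large group, gives [ a 1.3-fold lower number from compound 1 to compound 3 (0.10 log units; within the scatter) ]. Among these compounds, this is the first direct comparison at this position on the core of compound 1, and on this read-out it does not separate the group without a ring from the group with a five-membered non-aromatic ring. No data on hand bear on why the two groups read alike.

From the compounds shown here alone, whether any group at this position can give a step beyond the scatter remains open. A primary amine or a carboxylic acid in this place, or a chain longer than the ethyl of (ethylcarbamoyl)amino, would test that directly.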